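A few compounds are considered here, and "the series" means these few. Any claim that something is new, unique, unknown or untested is made for them only; others in the source may bear on it.

Measured compounds: compound 1 `Fc1ccc(-c2nn3c(NC4CCCC4)cccc3c2-c2ccc3[nH]ccc3c2)cc1` gives 20000 nM in an ADME assay on Vero cells (Chlorocebus sabaeus) for cytotoxicity; on this read-out higher numbers stand for lower toxicity in this test and lower numbers for higher toxicity in this test; for compound 2 `Nc1nc(-c2c(-c3ccc(F)cc3)nn3c(NC4CCCC4)cccc23)c[nH]1` the entry in this assay reads "not determined" (no result reported); for compound 3 `Fc1ccc(-c2nn3c(NC4CCCC4)cccc3c2-c2ccno2)cc1` the entry in this assay reads "not determined" (no result reported).

Compound 3 stands nowhere on the numbers: in this assay compound 3 has no value, compound 2 shares that gap, and compound 1 alone supplies a figure. Compound 4 `Fc1ccc(-c2nn3c(NC4CCCC4)cccc3c2-c2cn[nH]c2)cc1` differs from compound 3 by 1H-pyrazol-4-yl in place of 1,2-oxazol-5-yl on an aromatic carbon. Among the compounds with values here, no step between two measured compounds exists to calibrate this change, so the expected step in this assay from compound 3 to compound 4 is none beyond the usual scatter, in either direction, with the single value of compound 1 as the only anchor. Compound 4 is thus expected to give about 20000 nM in this assay, within an estimated range of 7000 nM to 60000 nM.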

Compound 4, half-maximal cytotoxic concentration: 10000 nM
For compound 4 the middle estimate is 2.0-fold (0.30 log units) above the measured one, within the range that was stated.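

In this assay, within the data shown here, the exchange of 1H-indol-5-yl for 1H-pyrazol-4-yl, on the aromatic carbon next to the ring atom that bears a 4-fluorophenyl group, gives a 2.0-fold lower number from compound 1 to compound 4 (0.30 log units; within the scatter) as the first readable step at this position. On this read-out the two groups cannot be told apart. Steps involving the entries without a value cannot be read, and no measurement offered here accounts for the result.

Going by these compounds, what an amine or a carboxylic acid on this carbon would give in this assay remains open.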